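Series notes: the step from compound 3 to compound 4

The compounds below may be only part of what the source reports. "The series", "measured", "known", "first", "only" and "open" are said of these compounds alone.

Measured so far:
Compound 1 `COc1ncc(-c2ccc3c(c2)N(c2ccc(F)cc2)C(=O)CO3)cc1NS(=O)(=O)c1ccc(F)cc1` gives only a limit in a functional assay on A-375 cells (Homo sapiens) for antiproliferative activity, read by MTT assay, with a stated time of 72 h (a higher number here means a weaker inhibitor, a lower number a stronger inhibitor), namely > 40000 nM.
Compound 2 `COc1ncc(-c2ccc3c(c2)N(C2CCCCC2)C(=O)CO3)cc1NS(=O)(=O)c1ccc(F)cc1` also gives only a limit in this assay, namely > 40000 nM.
Compound 3 `O=C1COc2ccc(-c3cnc(Cl)c(NS(=O)(=O)c4ccc(F)cc4)c3)cc2N1C1CC1` gives 21800 nM in this assay.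

For the measured compounds named here, compound 3 holds the only numerical value in the set; the other two entries are limits of the assay, as summarised by the limit of > 40000 nM in this assay, at which 2 of the 3 values shown sit. The step that the two limits leave unreadable from compound 1 to compound 2 has both ends at the limit and cannot be read in size. Compound 4 `COc1ncc(-c2ccc3c(c2)N(C2CC2)C(=O)CO3)cc1NS(=O)(=O)c1ccc(F)cc1` is not yet measured. It differs from compound 3 by methoxy in place of chloro on an aromatic carbon. Going by the values given here, no measured step changes this group, so no measured step bears directly on it. Among the compounds with values here, the only guide is that compound 1 and compound 2, which both carry the methoxy, sit at the limit, while compound 3, which carries the chloro, gives a weak but readable number. The step of a 1.6-fold higher number from compound 3 to compound 4 (0.21 log units; within the scatter) is expected to go toward weaker inhibition, with a fair chance that only a limit is reported. Compound 4 is estimated at 35000 nM, within a range from 15000 nM to 80000 nM.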

Compound 4, half-maximal inhibitory concentration: 23900 nM
For compound 4 the middle estimate is 1.5-fold (0.17 log units) above the measured one; measured number inside the range.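

In this assay, methoxy in place of chloro on an aromatic carbon next to the ring nitrogen gives a 1.1-fold higher number from compound 3 to compound 4 (0.04 log units; within the scatter), so with cyclopropyl on the amide-type nitrogen in a ring, this exchange leaves no readable difference. With methoxy held constant, cyclopropyl in place of cyclohexyl gives an at least 1.6-fold lower number from compound 2 to compound 4 (0.22 log units; that floor lies within the scatter), and cyclopropyl in place of 4-fluorophenyl gives an at least 1.6-fold lower number from compound 1 to compound 4 (0.22 log units; that floor lies within the scatter); each is only a floor, so neither step has a known full size. The methoxy alone therefore does not account for the entries for compound 1 and compound 2, which stand as limits: the limit of > 40000 nM in this assay, at which 2 of the 4 values shown sit.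

Going by these compounds, whether another group at this carbon, such as an amine or a methyl, would separate from chloro and methoxy remains open. Also open, on these data alone, is whether a longer chain or a hydroxyethyl group on the amide-type nitrogen would give a readable number in this assay.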